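This account rests on a few compounds, and the source may have more. Where it says the series, first, only, none or still open, it means among the compounds named here.

Series notes, shared core as drawn in compound 1.

Of the compounds shown here, two have been measured in a functional assay on UACC-257 cells (Homo sapiens) for cytotoxicity, read by sulforhodamine B assay, with a stated time of 48 h, tested at 0.01 uM; a higher number here means a weaker effect of the compound at the concentration tested, a lower number a stronger effect. Compound 1 `COc1ccc(-c2cc(/C=C/C(=O)c3ccc(N)cc3)[nH]n2)cc1` gives 96% in this assay. Compound 2 `COc1cc(-c2cc(/C=C/C(=O)c3ccc(N)cc3)[nH]n2)cc(OC)c1OC` gives 94% in this assay. On the numbers shown, compound 2 stands nearest to compound 1, the two values lying within the scatter of each other, so no order can be read between them: both sit near the top of the scale, and at this concentration neither shows more than a marginal effect.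

The next step goes from compound 2 to compound 3 `COc1ccc(-c2cc(/C=C/C(=O)c3ccc(N)cc3)[nH]n2)cc1OC`, which has not yet been measured in this assay. The change is hydrogen in place of methoxy on an aromatic carbon, that is, a hydrogen in place of a methoxy on an aromatic carbon, so that compound 3 carries fewer methoxy groups than compound 2 and more than compound 1. Going by the values given here, no measured step of this kind exists. Since compound 1 and compound 2 bracket the change and give values within the scatter of each other, the step of a number 1 percentage points higher from compound 2 to compound 3 (within the scatter) is expected to be none beyond the scatter. Compound 3 is estimated at 95% in this assay, within 85% to 102%.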

Compound 3, a percentage reported as activity, at one concentration (the size of the read-out at that concentration, not a potency): 90%
The estimate for compound 3 lay 5 percentage points above the measured number, within the range that was stated.
By their numbers in this assay, from the lowest: compounds 3, 2 and 1 (each within the scatter of the next).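

In this assay, the methoxy groups on this aromatic ring can now be judged through single changes rather than through a comparison of two compounds that differ in two places: hydrogen in place of methoxy gives a number 4 percentage points lower from compound 2 to compound 3 (within the scatter), and methoxy in place of hydrogen gives a number 6 percentage points lower from compound 1 to compound 3 (within the scatter). Neither change, in either of these two single steps, moves the read-out beyond the scatter at this concentration, so no contribution of a methoxy group at these positions can be read from these numbers, and no order can be set among the three compounds. No independent measurement bears on this result, and the numbers alone offer no explanation for it.

From the compounds shown here alone, all three compounds show little effect at this one concentration, so it remains open whether the same changes would separate the compounds at a concentration where the effect is larger. Going by these compounds, it also remains open whether a hydroxyl group, a fluorine atom, an amine or a longer chain such as ethoxy on this aromatic carbon would give a step beyond the scatter.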